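Swapping the chain on the ring nitrogen for a fluorophenyl

This account rests on a few compounds, and the source may have more. Where it says the series, first, only, none or still open, it means among the compounds named here.

Measured compounds:
Compound 1, `CCn1c(-c2ccc(OCc3c(-c4c(Cl)cccc4Cl)noc3C(C)C)cc2)nc2ccc(C(=O)O)cc21`: 2.31 nM
Compound 2, `CCCn1c(-c2ccc(OCc3c(-c4c(Cl)cccc4Cl)noc3C(C)C)cc2)nc2ccc(C(=O)O)cc21`: 9.3 nM

Of the compounds shown here, two have been tested in an assay on Huh-7 cells for agonist activity at Bile acid receptor (Homo sapiens), read by a luciferase reporter (a higher number here means that more compound is needed for the effect, a lower number that less compound is needed), so far. Compound 1 gives 2.31 nM and compound 2 gives 9.3 nM, so compound 2 stands with the higher of the two numbers, and the step of a 4.0-fold higher number from compound 1 to compound 2 (0.60 log units; beyond the scatter) lies beyond the scatter.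

Compound 3, `CC(C)c1onc(-c2c(Cl)cccc2Cl)c1COc1ccc(-c2nc3ccc(C(=O)O)cc3n2-c2ccc(F)cc2)cc1`, has not yet been measured. Compared with compound 2 the change is 4-fluorophenyl in place of propyl on an aromatic nitrogen; the group sits on an aromatic nitrogen of a five-membered aromatic ring with two nitrogens, part of a fused system of two rings.

Among the compounds with values here, only one measured step bears on this position: lengthening the chain, a 4.0-fold higher number from compound 1 to compound 2 (0.60 log units; beyond the scatter), raised the number modestly. Whether a flat aromatic group in place of a chain continues that trend is not shown by the data. A weaker compound, or one about as potent as compound 2, is expected; the estimate is that compound 3 gives 14 nM in this assay, within 3.5 nM to 60 nM, meaning an expected step of a 1.5-fold higher number from compound 2 to compound 3 (0.18 log units; within the scatter).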

Compound 3, half-maximal effective concentration: 32.2 nM
Estimate against measurement, compound 3: 2.3-fold (0.36 log units) below; measured number inside the range.
By their numbers in this assay, from the lowest: compound 1; then compound 2; then compound 3.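

In this assay the ring nitrogen still carries a working compound when its chain gives way to an aromatic ring: compound 3 gives 32.2 nM with the 4-fluorophenyl group in place. That replacement has a clear cost, however, with a 3.5-fold higher number from compound 2 to compound 3 (0.54 log units; beyond the scatter) against the propyl compound and a 14-fold higher number from compound 1 to compound 3 (1.14 log units; beyond the scatter) against the ethyl compound, the larger of the two steps and the only large one seen so far. Across these three compounds the ethyl group therefore gives the lowest number, the propyl group comes next and the 4-fluorophenyl group gives the highest, but nothing in the data explains why the number rises with this change.

Since the ring and its fluorine enter together, the compounds shown cannot separate what each contributes, and an unsubstituted phenyl group would be needed to tell them apart. They also leave open whether a smaller group such as methyl or a small saturated ring such as cyclopropyl would give a lower number than the ethyl group does, or whether ethyl already lies close to the best size at this nitrogen.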